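The compounds below may be only part of what the source reports. "The series", "measured", "known", "first", "only" and "open" are said of these compounds alone.

Compound 1 `CN1CCN(c2ccc(NC(=N)c3cc4cn[nH]c4cn3)cc2)CC1`: 31300 nM
Compound 2 `N=C(Nc1ccccc1)c1cc2c(-c3ccccc3)n[nH]c2cn1`: 22000 nM

Both compounds were tested in a functional assay on HT-1080 cells (Homo sapiens) for cytotoxicity, read by MTT assay, with a stated time of 72 h; a lower number here means a stronger inhibitor, a higher number a weaker inhibitor. Compound 2 gives 22000 nM in this assay, and compound 1 gives 31300 nM; the two numbers lie within the scatter of each other, so the data do not separate them. Compound 3 `CN1CCN(c2ccc(NC(=N)c3cc4c(-c5ccccc5)n[nH]c4cn3)cc2)CC1` differs from compound 2 in a single place: 4-methylpiperazin-1-yl in place of hydrogen on an aromatic carbon. For the measured compounds named here, no pair of measured compounds isolates this change, since compound 1 carries the same 4-methylpiperazin-1-yl group but differs from compound 2 in more than that one place. On the two values at hand, a step from compound 2 to compound 3 in this assay of no more than the usual scatter is expected, in either direction. Compound 3 is therefore estimated at 18000 nM in this assay, with a range from 6000 nM to 50000 nM. The expected step in this assay is a 1.2-fold lower number from compound 2 to compound 3 (0.09 log units; within the scatter).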

Compound 3, half-maximal inhibitory concentration: 11400 nM
The estimate for compound 3 lay 1.6-fold (0.20 log units) above the measured number, and the stated range covers the measured number.
By their numbers in this assay, from the lowest: compounds 3, 2 and 1 (each within the scatter of the next, the first and the last beyond it).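

For the compounds shown here, compound 3 gives the first matched readings for both changes in this assay. With 4-methylpiperazin-1-yl in place of hydrogen on an aromatic carbon, para to a large group, the data show a 1.9-fold lower number from compound 2 to compound 3 (0.29 log units; within the scatter) and so do not separate the two compounds. Phenyl in place of hydrogen on an aromatic carbon, with 4-methylpiperazin-1-yl present, gives a 2.7-fold lower number from compound 1 to compound 3 (0.44 log units; beyond the scatter) and is the only one of the two changes to pass beyond the scatter, though modestly. Nothing available bears on the cause of either step.

The compounds shown leave open whether the phenyl step would hold in a compound without the 4-methylpiperazin-1-yl group. They also leave open how a morpholine, a dimethylamino group or a carboxylic acid at the same place would read in this assay.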